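The source may hold more compounds than are shown below. What is called first, only, known or untested is meant among the compounds shown, and "the series" means these compounds.

Of the compounds shown here, three share one core and have been tested in a functional assay on Maver1 cells (Homo sapiens) for inhibition, read by luminescence and CellTiter-Glo, with a stated time of 72 h; on this read-out lower numbers stand for stronger inhibition and higher numbers for weaker inhibition. Compound 2 `C/C=C/C(=O)Nc1ccc(Cn2nc(-c3ccc(Oc4ccccc4)cc3)cc2CO)cc1` gives 48400 nM. Compound 1 `C/C=C/C(=O)Nc1ccc(Cn2nc(-c3ccc(Oc4ccccc4)cc3)cc2C(=O)O)cc1` gives > 60000 nM, and that is a limit of the assay rather than a number. Going from compound 2 to compound 1 means (carboxy in place of hydroxymethyl on an aromatic carbon), and the step is an at least 1.2-fold higher number from compound 2 to compound 1 (0.09 log units; that floor lies within the scatter). Compound 3 `O=C(CCl)Nc1cccc(Cn2nc(-c3ccc(Oc4ccccc4)cc3)cc2CO)c1` gives 400 nM, the lowest of the two measured numbers; how its core differs from the core of compound 2 is not broken down here. Compound 4 `O=C(CCl)Nc1cccc(Cn2nc(-c3ccc(Oc4ccccc4)cc3)cc2C(=O)O)c1` is not yet measured and differs from compound 3 by carboxy in place of hydroxymethyl on an aromatic carbon, the same change as from compound 2 to compound 1. For compound 1 that earlier step reached only (the limit of > 60000 nM in this assay, at which 1 of the 3 values shown sits), so its full size is not known. A modest rise is expected for compound 4, a 3.8-fold higher number from compound 3 to compound 4 (0.57 log units; beyond the scatter). Compound 4 is therefore estimated at 1500 nM, between 400 nM and 6000 nM.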

Compound 4, half-maximal inhibitory concentration: 4700 nM
Estimate against measurement, compound 4: 3.1-fold (0.50 log units) below, within the range that was stated.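

Carboxy in place of hydroxymethyl weakens inhibition clearly in this assay, where the step is a 12-fold higher number from compound 3 to compound 4 (1.07 log units; beyond the scatter). This shows a large effect on one core, but it does not show that the change has the same size on the other core: the same change on two cores in this assay, an at least 1.2-fold higher number (0.09 log units; that floor lies within the scatter) from compound 2 to compound 1 and a 12-fold higher number (1.07 log units; beyond the scatter) from compound 3 to compound 4; the limit leaves it open whether they differ. Compound 1 gives > 60000 nM, which is a limit and not a number: the limit of > 60000 nM in this assay, at which 1 of the 4 values shown sits.

The compounds shown leave open how a methyl ester, a primary amide or an aminomethyl group at this place would compare with carboxy and hydroxymethyl on either core. On these data alone, whether a step of this size would hold on a third core also stays open.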